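Chloro for methyl on the anilide ring of a chromone amide

The compounds below may be only part of what the source reports. "The series", "measured", "known", "first", "only" and "open" are said of these compounds alone.

The measured compounds are: compound 1 `Cc1cccc(NC(=O)c2coc3ccc(C)cc3c2=O)c1`, compound 2 `Cc1ccc2occ(C(=O)Nc3cccc(Cl)c3)c(=O)c2c1`, and compound 3 `COc1ccc2occ(C(=O)Nc3ccc(C)cc3)c(=O)c2c1`. In an assay on cells for inhibition of Amine oxidase [flavin-containing] B (Homo sapiens), read by fluorescence and Amplex Red, using microsomes, with a stated time of 15 min (a higher number here means a weaker inhibitor, a lower number a stronger inhibitor), compound 1 gives 17.1 nM, compound 2 gives 4.2 nM, and compound 3 gives 211 nM.

Compound 2 differs from compound 1 by chloro in place of methyl on an aromatic carbon, and this change produced a 4.1-fold lower number from compound 1 to compound 2 (0.61 log units; beyond the scatter). Compound 4 `COc1ccc2occ(C(=O)Nc3ccc(Cl)cc3)c(=O)c2c1`, not yet measured, differs from compound 3 by chloro in place of methyl on an aromatic carbon. The difference between the cores of compound 1 and compound 3 is not broken down here. The two changes are the same kind of change, not the same: in compound 1 the ring carbon is meta to a large group, in compound 3 it is para to a large group.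

Because compound 3 stands at 211 nM, compound 4 is expected to show a step of about a 3.5-fold lower number from compound 3 to compound 4 (0.55 log units; beyond the scatter), near the earlier one. The expected value of compound 4 is 60 nM, estimated between 25 nM and 150 nM.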

Compound 4, half-maximal inhibitory concentration: 10.3 nM
For compound 4 the middle estimate is 5.8-fold (0.77 log units) above the measured one, outside the stated range (below it).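

Chloro in place of methyl gives a 20-fold lower number from compound 3 to compound 4 (1.31 log units; beyond the scatter), so the direction of the step seen on the first pair holds on this one. Its size does not carry over from one core to the other: the same change on two cores in this assay, a 4.1-fold lower number (0.61 log units; beyond the scatter) from compound 1 to compound 2 and a 20-fold lower number (1.31 log units; beyond the scatter) from compound 3 to compound 4, 5.0-fold (0.70 log units) apart, beyond the scatter of two such steps The two pairs differ in the core and also in where the change sits on the ring, so they cannot show which of the two sets the size of the step, and two pairs make no general rule.

The compounds shown leave open how the same change behaves when only its place on the ring differs on a single core. They also leave open what a fluoro, a trifluoromethyl or an amine would do in that place.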